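The compounds below may be only part of what the source reports. "The series", "measured", "known", "first", "only" and "open" are said of these compounds alone.

Measured so far:
compound 1, `Cc1cccc(Cc2nc3cc(O[C@H]4CC[C@@H](C(=O)O)CC4)ccc3n2C)c1`, in an assay on isolated protein for inhibition of Long-chain-fatty-acid--CoA ligase 1 (Mus musculus), read by mass spectrometry, with a stated time of 90 min, in the presence of a further agent that is not named here; on this read-out lower numbers stand for stronger inhibition and higher numbers for weaker inhibition: 30 nM
compound 2, `Cc1cccc(Cc2c(C(N)=O)c3cc(O[C@H]4CC[C@@H](C(=O)O)CC4)ccc3n2C)c1`, in this assay: 440 nM

Compound 1 has the lower of these two numbers, and on this read-out the lower number is the stronger inhibition. The gap between compound 1 and compound 2 is beyond the usual scatter, so compound 1 is the stronger inhibitor of the pair. The two compounds are not a simple one-place pair, however, so their gap cannot be tied to a single change.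

Compound 3, `Cn1c(Cc2cccc(C(F)(F)F)c2)nc2cc(O[C@H]3CC[C@@H](C(=O)O)CC3)ccc21`, has not yet been measured. It differs from compound 1 in one place: trifluoromethyl in place of methyl on an aromatic carbon. The 3-methylphenyl of compound 1 thus becomes a 3-(trifluoromethyl)phenyl, with everything else kept.

Going by the values given here, no measured pair shows this change, so there is no direct guide to its size. In the absence of such a step, the expectation is a change from compound 1 to compound 3 of a 1.3-fold higher number from compound 1 to compound 3 (0.12 log units; within the scatter), that is, no step beyond the scatter in either direction. Compound 3 is therefore estimated at 40 nM, with a range from 12 nM to 130 nM.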

Compound 3, half-maximal inhibitory concentration: 86 nM
Compound 3: middle estimate off by 2.2-fold (0.33 log units), on the low side; the measured number falls inside the stated range.
By their numbers in this assay, from the lowest: compound 1; then compound 3; then compound 2.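

Going by these compounds alone, this is the first step that can be tied to a single place: in this assay, putting trifluoromethyl in place of methyl on the aromatic ring gives a 2.9-fold higher number from compound 1 to compound 3 (0.46 log units; beyond the scatter) and so shows that inhibition responds to what sits at this position. The step is modest, and with 4 heavy atoms in place of 1, compound 3 still reads 86 nM, so the larger group weakens inhibition without abolishing it. Nothing at hand gives a measured reason for this step, so the numbers record its size and direction but not its cause.

From the compounds shown here alone, a single change at a single position cannot show a trend, and it remains open whether a hydrogen, a chlorine or a methoxy group at this place would read closer to compound 1 or to compound 3. Going by these compounds, it is also open whether the same change from 3-methylphenyl to 3-(trifluoromethyl)phenyl would produce a step of similar size on the core of compound 2, which carries a primary amide.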